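The compounds below may be only part of what the source reports. "The series", "measured", "known", "first", "only" and "open" are said of these compounds alone.

Measured compounds:
compound 1 `COc1ccc(C(=O)Nc2ccc(-c3ccncc3)cc2)cc1CCCN(C)C` gives 10 nM in an assay on striatum for binding affinity to 5-hydroxytryptamine receptor 1D (Cavia porcellus), in the presence of a further agent that is not named here; on this read-out higher numbers stand for weaker inhibition and lower numbers for stronger inhibition;
compound 2 `COc1ccc(C(=O)Nc2ccc(-c3ccc(C=O)cc3C)cc2)cc1CCCN(C)C` gives 6.31 nM in this assay;
compound 3 `COc1ccc(NC(=O)c2ccc(-c3ccc(C(=O)N(C)C)cc3C)cc2)cc1N1CCN(C)CC1` gives 5.01 nM in this assay.

Compound 2 stands in the middle of these three numbers, its separation from compound 1 and from compound 3 lying within the scatter on both sides, so the three cannot be told apart. Going by the values given here, the one measured step, a 1.6-fold lower number from compound 1 to compound 2 (0.20 log units; within the scatter), changed the outer ring and not the carbonyl, and nothing else in the set touches the site now altered. Compound 4 `COCCOC(=O)c1ccc(-c2ccc(NC(=O)c3ccc(OC)c(CCCN(C)C)c3)cc2)c(C)c1` differs from compound 2 by 2-methoxyethoxy in place of hydrogen on a carbonyl carbon. Among the compounds with values here, no measured step bears directly on this change, and the only step recorded stayed within the scatter, so a step in this assay of no more than the scatter is expected, in no particular direction. On that basis compound 4 is expected to give about 7 nM, in the range 2.5 nM to 20 nM, which is an expected step of a 1.1-fold higher number from compound 2 to compound 4 (0.05 log units; within the scatter).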

Compound 4, inhibition constant: 3.16 nM
Compound 4: middle estimate off by 2.2-fold (0.35 log units), on the high side; measured number inside the range.
By their numbers in this assay, from the lowest: compounds 4, 3, 2 and 1 (each within the scatter of the next, the first and the last beyond it).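

In this assay, going by these compounds alone, the carbonyl carbon of compound 2 carries a hydrogen, and the new result is the first to test a change at this site: with 2-methoxyethoxy in its place, formyl becomes (2-methoxyethoxy)carbonyl, and the read-out shows a 2.0-fold lower number from compound 2 to compound 4 (0.30 log units; within the scatter). This site therefore accepts a chain of 5 heavy atoms with no ring and no net charge, with a step no larger than the scatter, so this pair shows no measurable gain or loss from the change. No available evidence bears on why the number responds in this way. The compounds shown leave open whether a carboxylic acid, a methyl ester or an amide on the same carbonyl carbon would also stay within the scatter of compound 2. They also leave open whether a longer chain ending in an amine would do so.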